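The source may report more compounds than this note shows. Statements on the series, on what has been measured and on what is new or still open speak of the compounds shown alone.

The set has three measured compounds and one still to be tested. Compound 1 `Nc1nc(=O)ccn1COCCO` was run in a functional assay (Oryctolagus cuniculus) for inhibition; a lower number here means a stronger inhibitor, a higher number a weaker inhibitor; the result for compound 1 is a limit of the assay, > 400 ug/mL. Compound 2 `O=c1[nH]c(=O)n(COCCO)cc1/C=C/Br` likewise returned a limit in this assay, namely > 400 ug/mL. Going by the values given here, compound 3 `Nc1nc2c(nc(Br)n2COCCO)c(=O)[nH]1` is the only one to yield a number, giving 225 ug/mL in this assay, so it stands alone as the single measured figure while the other two rest at the limit of > 400 ug/mL in this assay, at which 2 of the 3 values shown sit. Among the compounds with values here, no pair of measured compounds differs in one place, so no measured step is available as a guide.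

Compound 4 `Nc1nc2c(nc(N)n2COCCO)c(=O)[nH]1` differs from compound 3 by amino in place of bromo on an aromatic carbon. Within the data shown here, nothing among the measured compounds shows what such a change does in this assay. The chemist therefore expects the step to be modest, a 1.3-fold higher number from compound 3 to compound 4 (0.12 log units; within the scatter), with the direction uncertain. For compound 4 in this assay the estimate is 300 ug/mL, with a range from 100 ug/mL to 800 ug/mL, and a real chance that only a limit is reported.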

Compound 4, concentration for 50% inhibition: 200 ug/mL
Compound 4: the middle estimate sits 1.5-fold (0.18 log units) above what was measured; the range from low to high includes it.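

In this assay, going by these compounds alone, amino in place of bromo on the aromatic carbon between two ring nitrogen atoms gives a 1.1-fold lower number from compound 3 to compound 4 (0.05 log units; within the scatter), the first step in the set that can be read. At this position, then, a bromine and a nitrogen substituent give readings that cannot be told apart, even though amino brings a hydrogen-bond donor and a hydrogen-bond acceptor that bromo lacks. Nothing measured here offers a cause for this result.

As far as these compounds go, whether a hydrogen, a methyl group, a carboxylic acid or a phenyl ring at this carbon would read any differently remains open. So does the contribution of the (2-hydroxyethoxy)methyl group, and the cores of compound 1 and compound 2 are not linked to the others by any single-place step.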